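Second chloro on the para-substituted purine series

The compounds below may be only part of what the source reports. "The series", "measured", "known", "first", "only" and "open" are said of these compounds alone.

The study begins with compound 1 `ClCc1ccccc1Cn1cnc2c(Cl)nc(Cl)nc21`, which in a functional assay on CCRF-CEM cells (Homo sapiens) for cytotoxicity, read by sulforhodamine B assay, with a stated time of 48 h (a higher number here means that more compound is tolerated, a lower number that less compound is tolerated), gives 470 nM. Compound 2 `ClCc1ccc(Cn2cnc3ncnc(Cl)c32)cc1` carries the chloromethylbenzyl group in a different position and has a single chloro on its core; in this assay compound 2 gives "not determined" (no result reported), so it stands at no number at all. Compound 3 `ClCc1ccc(Cn2cnc3nc(Cl)nc(Cl)c32)cc1` is the next member. It differs from compound 2 by chloro in place of hydrogen on an aromatic carbon. With no number for compound 2, the step to compound 3 in this assay cannot be placed against it in either direction, and no change beyond the scatter can be claimed or denied. The expectation for compound 3 therefore rests on compound 1 alone, which shares the two chloro groups on the core. Because compound 1 gives 470 nM, compound 3 is expected to give about 500 nM in this assay, within a range of 150 nM to 1600 nM.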

Compound 3, concentration lethal to 50% of the cells: 66100 nM
Estimate against measurement, compound 3: 130-fold (2.12 log units) below; the measured number lies above the stated range.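

Among these compounds, compound 2 has no number in this assay, and no step to compound 3 can be read from it. The compounds shown leave open what chloro in place of hydrogen does on its own in this assay. No supporting evidence bears on the result for compound 3.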